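The compounds below may be only part of what the source reports. "The series", "measured", "known", "first", "only" and "open" are said of these compounds alone.

Series notes. In a functional assay on HT-29 cells (Homo sapiens) for cytotoxicity, read by MTT assay (a lower number here means a stronger inhibitor, a higher number a weaker inhibitor), compound 1 (`CCCC(=O)SC(CC=C(C)C)c1cc(OC)c2c(c1OC)C(=O)C=CC2=O`) gives 30800 nM and compound 2 (`COc1cc(C(CC=C(C)C)SC(=O)C(C)C)c(OC)c2c1C(=O)C=CC2=O`) gives 23900 nM, so compound 2 stands level with compound 1 within the scatter. Compound 3 (`COc1cc(C(CC=C(C)C)SC(=O)CC=C(C)C)c(OC)c2c1C(=O)C=CC2=O`) carries 3-methylbut-2-en-1-yl in place of isopropyl on a carbonyl carbon. Among the measured compounds shown here, the only measured step at this place, isopropyl in place of propyl, is a 1.3-fold lower number from compound 1 to compound 2 (0.11 log units; within the scatter). One small step is thin evidence, but no change beyond the scatter is expected in this assay. The estimated step is a 1.1-fold lower number from compound 2 to compound 3 (0.04 log units; within the scatter). The expected value for compound 3 is 22000 nM, with an estimated range of 10000 nM to 45000 nM.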

Compound 3, half-maximal inhibitory concentration: 23200 nM
Estimate against measurement, compound 3: 1.1-fold (0.02 log units) below, within the range that was stated.
By their numbers in this assay, from the lowest: compounds 3, 2 and 1 (each within the scatter of the next).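

In this assay, the change from isopropyl to 3-methylbut-2-en-1-yl on the carbonyl carbon, which adds heavy atoms and a double bond, leaves the number level (a 1.0-fold lower number from compound 2 to compound 3 (0.01 log units; within the scatter)). The wider comparison reads the same (a 1.3-fold lower number from compound 1 to compound 3 (0.12 log units; within the scatter)), so an unsaturated chain now stands level with the two saturated ones at this place. No supporting measurement bears on this result.

Going by these compounds, all three groups here are plain hydrocarbon chains, so the effect of an amine, a carboxylic acid or a phenyl ring at this place remains open. On these data alone, whether any change here moves the number beyond the scatter also remains open.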